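The source may report more compounds than this note shows. Statements on the series, on what has been measured and on what is new or still open speak of the compounds shown alone.

Among the measured compounds shown here, in a functional assay on A549 cells (Homo sapiens) for inhibition, read by sulforhodamine B assay (a lower number here means a stronger inhibitor of growth, a higher number a weaker inhibitor of growth), compound 2 `COc1ccc(-c2ccc(-c3ccc(-c4nc5c(O)cccc5[nH]4)cc3)cc2)cc1` gives 7690 nM, the higher of the two numbers so far, and compound 1 `Oc1cccc2[nH]c(-c3ccc(-c4ccc(-c5ccc(F)cc5)cc4)cc3)nc12` gives 170 nM. Compound 3 `Oc1cccc2[nH]c(-c3ccc(-c4ccc(-c5cccc(Cl)c5)cc4)cc3)nc12` has 3-chlorophenyl in place of 4-methoxyphenyl on an aromatic carbon, para to a large group: 3-chlorophenyl in place of 4-methoxyphenyl on an aromatic carbon. For the measured compounds named here, one measured step bears on this, the large rise a 45-fold higher number from compound 1 to compound 2 (1.66 log units; beyond the scatter), with methoxy in place of fluoro. Going by the values given here, compound 3 also loses the methoxy, so a large fall in this assay is expected, though no measured compound carries chlorine. The estimated step is a 13-fold lower number from compound 2 to compound 3 (1.11 log units; beyond the scatter). For compound 3 the expected value is 600 nM, within a range of 120 nM to 3000 nM.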

Compound 3, concentration for 50% growth inhibition: 2400 nM
Compound 3: the middle estimate sits 4.0-fold (0.60 log units) below what was measured; low and high end bracket the measured number.
By their numbers in this assay, from the lowest: compound 1; then compound 3; then compound 2.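

In this assay, 3-chlorophenyl recovers only part of the loss seen with 4-methoxyphenyl (a 3.2-fold lower number from compound 2 to compound 3 (0.51 log units; beyond the scatter)) and stays far from 4-fluorophenyl (a 14-fold higher number from compound 1 to compound 3 (1.15 log units; beyond the scatter)). Losing the methoxy is thus not enough to return to the number of compound 1, which remains the lowest of the three, with its steps to both others beyond the scatter. No measurement given here accounts for these gaps.

The compounds shown do not separate the effect of the chlorine from that of its placement, as 3-chlorophenyl differs from 4-fluorophenyl in both. Also open, on these data alone, is how an amine or a carboxylic acid in this place would compare.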